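The source may report more compounds than this note shows. Statements on the series, on what has been measured and on what is new or still open speak of the compounds shown alone.

Working notes on the series.

Of the compounds shown here, three sharing one core have been measured in a functional assay on OVCAR-8 cells (Homo sapiens) for inhibition, read by sulforhodamine B assay, with a stated time of 48 h; a lower number here means a stronger inhibitor of growth, a higher number a weaker inhibitor of growth. Compound 1 `Nc1cc(N)c2nc(-c3ccccc3)c(Oc3ccc(Cl)c(Cl)c3)nc2c1` gives 28200 nM. Compound 3 `CCOC(=O)[C@H](CCC(=O)O)NC(=O)c1ccc(Oc2nc3cc(N)cc(N)c3nc2-c2ccccc2)cc1` gives 38000 nM; the numbers of compound 1 and compound 3 lie within the scatter of each other, so no order between them is claimed. Compound 2 `COc1cc(CNc2nc3cc(N)cc(N)c3nc2-c2ccccc2)cc(OC)c1OC` gives 6920 nM, a lower number than compound 1 by a margin beyond the scatter. Among the three numbers, compound 1 therefore holds the second highest, with compound 3 nearest to it and compound 2 furthest.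

The step under consideration is from compound 1 to compound 4 `Nc1cc(N)c2nc(-c3ccccc3)c(NCc3ccc(F)cc3)nc2c1`, not yet measured in this assay. The change is (4-fluorobenzyl)amino in place of 3,4-dichlorophenoxy on an aromatic carbon. For the measured compounds named here, no step between two measured compounds differs in only one place, so there is no directly comparable precedent for the size of this step.

With compound 2 at 6920 nM showing that numbers below compound 1 occur within this series, a modest step toward a lower number is expected for compound 4, of the size a 2.4-fold lower number from compound 1 to compound 4 (0.37 log units; beyond the scatter). The estimate for compound 4 in this assay is 12000 nM, with a range from 3500 nM to 40000 nM.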

Compound 4, concentration for 50% growth inhibition: 2630 nM
The estimate for compound 4 lay 4.6-fold (0.66 log units) above the measured number; the measured number lies below the stated range.
By their numbers in this assay, from the lowest: compound 4; then compound 2; then compounds 1 and 3 (each within the scatter of the next).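

Working notes, continued. In this assay, for the compounds shown here, this is the first change at a single place that can be read: an 11-fold lower number from compound 1 to compound 4 (1.03 log units; beyond the scatter) accompanies (4-fluorobenzyl)amino in place of 3,4-dichlorophenoxy on the aromatic carbon next to the ring nitrogen, so the number depends strongly on the group at this position. The two groups match in heavy-atom count and each holds one six-membered aromatic ring of carbon only, yet the step changes the linking atoms, the halogens and the hydrogen-bond donor together, and it cannot assign the shift to any one of them. Compound 2, also a substituted benzyl on an amino link, gives 6920 nM in the same assay, while compound 4 gives 2630 nM there, and neither compound has a measurement that accounts for the step.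

Open, on these data alone, is whether the amino link or the benzyl part carries the shift, which a 4-fluorobenzyloxy group or a 3,4-dichlorobenzylamino group at this position would separate. Also open, as far as these compounds go, is how the number responds to a methyl on the amino nitrogen or to a longer chain between that nitrogen and the ring.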